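From compound 1 to compound 4: a carboxy chain

This account rests on a few compounds, and the source may have more. Where it says the series, first, only, none or still open, it means among the compounds named here.

Compound 1 `COc1cc(C(=O)c2ccc3[nH]ccc3c2)cc(OC)c1OC` gives 104 nM
Compound 2 `CCn1ccc2cc(C(=O)c3cc(OC)c(OC)c(OC)c3)ccc21` gives 36 nM
Compound 3 `COc1cc(C(=O)c2ccc3c(ccn3CC(=O)O)c2)cc(OC)c1OC` gives 520 nM

These three values come from a functional assay on KB cells (Homo sapiens) for inhibition, with a stated time of 72 h; a higher number here means a weaker inhibitor, a lower number a stronger inhibitor. Compound 1 stands in the middle, with compound 2 lower and compound 3 higher. Compound 4 `COc1cc(C(=O)c2ccc3c(ccn3CCC(=O)O)c2)cc(OC)c1OC` has not been measured yet. Its difference from compound 1 is 2-carboxyethyl in place of hydrogen on an aromatic nitrogen, which in words is 2-carboxyethyl in place of hydrogen on an aromatic nitrogen.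

Going by the values given here, three measured steps bear on this change. Ethyl in place of that hydrogen gave a 2.9-fold lower number from compound 1 to compound 2 (0.46 log units; beyond the scatter), a modest step. Carboxymethyl in the same place gave a 5.0-fold higher number from compound 1 to compound 3 (0.70 log units; beyond the scatter), also modest and in the opposite direction. Carboxy in place of methyl on the chain gave a 14-fold higher number from compound 2 to compound 3 (1.16 log units; beyond the scatter), a large step. Compound 3 is the closest model, since its chain also ends in a carboxy group, so a modest rise in the number is expected in this assay. Among the compounds with values here, no measured pair shows what chain length alone does, so the range is kept wide. The expected outcome is a 4.3-fold higher number from compound 1 to compound 4 (0.64 log units; beyond the scatter). Compound 4 is estimated at 450 nM, within an expected range of 150 nM to 1300 nM.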

Compound 4, half-maximal inhibitory concentration: > 10000 nM
Compound 4 gave a limit, no number; the forecaster's own chance of this, stated with the estimate: 3%; middle value at least 22-fold (1.34 log units) from the limit.
By their numbers in this assay, from the lowest: compound 2; then compound 1; then compound 3. At a limit, above all of these: compound 4.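

In this assay, compound 4 stands at a limit of the assay and not at a number, so each step to it is only a minimum: the limit of > 10000 nM in this assay, at which 1 of the 4 values shown sits. On the aromatic nitrogen, 2-carboxyethyl gives an at least 96-fold higher number from compound 1 to compound 4 (1.98 log units; beyond the scatter), and the same chain set against the shorter carboxymethyl gives an at least 19-fold higher number from compound 3 to compound 4 (1.28 log units; beyond the scatter), which shows that among these two acids the length of the chain matters as well as the carboxy group at its end. Set against the ethyl chain, the change gives an at least 270-fold higher number from compound 2 to compound 4 (2.44 log units; beyond the scatter).

From the compounds shown here alone, how a plain propyl chain would compare with 2-carboxyethyl stays open, and that comparison would separate chain length from the carboxy group. Also open, going by these compounds, is whether an amine or a methyl ester at the end of the same chain would behave like the carboxylic acid.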